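Ethyl to 4-Fluoropiperidin-1-yl on a Carbonyl Carbon

This account rests on a few compounds, and the source may have more. Where it says the series, first, only, none or still open, it means among the compounds named here.

Compound 2 `CCC(=O)N1CCc2nc(C#Cc3ccccc3)sc2C1` carries ethyl on a carbonyl carbon, and in an assay on HEK293 cells for positive allosteric modulation of metabotropic glutamate receptor 5 (Homo sapiens), read by FLIPR, with a stated time of 1 h (on this read-out lower numbers stand for an effect already at smaller amounts and higher numbers for an effect only at larger amounts of compound), compound 2 gives > 10000 nM, which is a limit of the assay rather than a number; it sits at the limit of > 10000 nM in this assay, at which 1 of the 3 values shown sits. Compound 1 `O=C1NCCc2nc(C#Cc3ccccc3F)sc21` gives 1500 nM in this assay, while compound 3 `O=C(C1CCCCO1)N1CCc2nc(C#Cc3ccccc3)sc2C1` gives 320 nM. Among the measured compounds shown here, the one measured step that bears on the change is an at least 31-fold lower number from compound 2 to compound 3 (1.49 log units; beyond the scatter). Compound 4 `O=C(N1CCC(F)CC1)N1CCc2nc(C#Cc3ccccc3)sc2C1` differs from compound 2 by 4-fluoropiperidin-1-yl in place of ethyl on a carbonyl carbon; again a ring enters in place of ethyl on a carbonyl carbon, so a drop of comparable size is expected, its exact extent uncertain since the starting point is only a limit. Compound 4 is estimated at 1000 nM, within 200 nM to 8000 nM, an expected step of an at least 10-fold lower number from compound 2 to compound 4 (1.00 log units; beyond the scatter).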

Compound 4, half-maximal effective concentration: 74 nM
Estimate against measurement, compound 4: 14-fold (1.13 log units) above; measured number below the stated range.
By their numbers in this assay, from the lowest: compound 4; then compound 3; then compound 1. At a limit, above all of these: compound 2.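

Compound 4 shows, with an at least 130-fold lower number from compound 2 to compound 4 (2.13 log units; beyond the scatter) in this assay, that the drop seen with oxan-2-yl is not confined to that one ring on the carbonyl carbon. The two rings do not give the same number, as a 4.3-fold lower number from compound 3 to compound 4 (0.64 log units; beyond the scatter) shows for 4-fluoropiperidin-1-yl in place of oxan-2-yl. The step from compound 2 is only a bound, as compound 2 stands at a limit and not a number: the limit of > 10000 nM in this assay, at which 1 of the 4 values shown sits.

Whether the fluorine matters stays open, as plain piperidin-1-yl is not among the compounds shown. From the compounds shown here alone, whether morpholin-4-yl or an open-chain amine would serve on this carbonyl carbon also stays open.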